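This account rests on a few compounds, and the source may have more. Where it says the series, first, only, none or still open, it means among the compounds named here.

The measured compounds:
compound 1, `CCOC(=O)C1=C(C)NC(=O)NC1C1CCCC1`, 18%
compound 2, `CC1=C(C(=O)OC(C)C)C(C2CCCC2)N/C(=N/C#N)N1`, 3%
compound 3, `CCOC(=O)C1=C(C)N/C(=N\C#N)NC1c1cccs1`, 3%

All three numbers come from an assay on HeLa cells for displacement of a labelled ligand from adenosine receptor A3 (Homo sapiens), with a stated time of 180 min, tested at 1 uM; a higher number here means more inhibition at the concentration tested (going by the name of the read-out), a lower number less inhibition. Compound 3 stands level with compound 2 at the digits shown, the two of them together the lowest of the three numbers; the nearest neighbour is compound 2, with no change at the digits shown and so within the scatter. Among the measured compounds shown here, the furthest is compound 1, whose number is higher by a gap that lies beyond the scatter, though no single-point step between compound 1 and compound 3 has been set out, so only the two values themselves are on hand.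

Compound 4, `CCOC(=O)C1=C(C)N/C(=N\C#N)NC1c1ccccc1`, has not yet been measured in this assay. It differs from compound 3 in one place: phenyl in place of thiophen-2-yl on a saturated ring carbon. For the measured compounds named here, no step between two measured compounds isolates this exchange, so the expectation rests on compound 3 alone. Since a six-membered aromatic ring of carbon only takes the place of a five-membered aromatic ring with one hetero atom, the step expected from compound 3 to compound 4 is small, a number 2 percentage points higher from compound 3 to compound 4 (within the scatter), not beyond the scatter in either direction. Compound 4 is therefore estimated at 5%, within a range from -5% to 20%.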

Compound 4, a percentage reported as inhibition, at one concentration (the size of the read-out at that concentration, not a potency): 13%
Compound 4: middle estimate off by 8 percentage points, on the low side, and the stated range covers the measured number.
By their numbers in this assay, from the lowest: compounds 2, 3, 4 and 1 (each within the scatter of the next, the first and the last beyond it).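

Phenyl in place of thiophen-2-yl on the saturated ring carbon gives a number 10 percentage points higher from compound 3 to compound 4 (within the scatter) in this assay, and this is the first reading of a single exchange at this position, since the earlier compounds offered no pair that differed in one place. It shows that this carbon, next to the ring nitrogen and next to the ring atom that bears the ethoxycarbonyl group, can carry either of these two aromatic rings without a change beyond the scatter, although the step reaches the edge of that scatter and so gives no firm order between the two rings. Nothing on hand accounts for the size of this step.

The compounds shown leave open whether a methoxy group or an amine on the phenyl ring, or a longer chain in its place on this carbon, would carry the number beyond the scatter. They also leave open whether the same exchange of rings would read alike on the core of compound 1, which has a carbonyl in that part of the ring.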